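Thioester to amide on a coumarin-derived acid series

The compounds below may be only part of what the source reports. "The series", "measured", "known", "first", "only" and "open" are said of these compounds alone.

Measured compounds:
Compound 1, `CC(=O)OCc1ccc2oc(=O)c(C(=O)Oc3cccc(Br)c3)cc2c1`: 39.5%
Compound 2, `CC(=O)OCc1ccc2oc(=O)c(C(=O)Sc3cccc(Br)c3)cc2c1`: 79.6%

In a functional assay on HT-1080 cells (Homo sapiens), read by transwell migration, with a stated time of 24 h, tested at 0.1 uM (a higher number here means a weaker effect of the compound at the concentration tested, a lower number a stronger effect), compound 1 gives 39.5%, while compound 2 gives 79.6%, the higher of the two measured numbers. Going by the values given here, the single measured step, a number 40.1 percentage points higher from compound 1 to compound 2 (beyond the scatter), is the only one that bears on the next change, and it is large. Compound 3, `CC(=O)OCc1ccc2oc(=O)c(C(=O)Nc3cccc(Cl)c3)cc2c1`, is not yet measured; it differs from compound 2 by (3-chlorophenyl)amino in place of (3-bromophenyl)sulfanyl on a carbonyl carbon. Among the compounds with values here, no measured pair shows an amino group entering at this carbonyl carbon, so the direction cannot be read from the data. The available step shows only that the carbonyl substituent can shift this assay by a large amount, so a step of comparable size is possible in either direction. Compound 3 is expected to give 55%, with a range from 25% to 85%, and the expected step is a number 24.6 percentage points lower from compound 2 to compound 3 (beyond the scatter).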

Compound 3, a percentage reported as activity, at one concentration (the size of the read-out at that concentration, not a potency): 79.6%
The estimate for compound 3 lay 24.6 percentage points below the measured number; the range from low to high includes it.
By their numbers in this assay, from the lowest: compound 1; then compounds 2 and 3 (each within the scatter of the next).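

In this assay, (3-chlorophenyl)amino in place of (3-bromophenyl)sulfanyl on the carbonyl carbon gives no change at the digits printed from compound 2 to compound 3 (within the scatter), so a second replacement of the 3-bromophenoxy group now sits with the sulfanyl compound. Set against the ester directly, the same group gives a number 40.1 percentage points higher from compound 1 to compound 3 (beyond the scatter), which makes compound 1 the only one of the three that stands apart, and the large step seen earlier is not peculiar to the sulfur compound. Nothing shown here accounts for this result.

As far as these compounds go, compound 3 changes the linking atom and the halogen at once, so the share of each in this outcome stays open, and a (3-bromophenyl)amino group on the same carbonyl carbon would separate them. Also open, from the compounds shown here alone, is whether a 3-chlorophenoxy group would keep the number of compound 1.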